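The source may report more compounds than this note shows. Statements on the series, on what has been measured and on what is new or still open speak of the compounds shown alone.

Three compounds have been measured in a functional assay on DLD-1 cells (Homo sapiens) for cytotoxicity, read by colorimetric assay and MTT assay, with a stated time of 3 days, tested at 1 uM; on this read-out lower numbers stand for a stronger effect and higher numbers for a weaker effect at the one concentration tested:

Compound 1 `COc1ccc(-c2nc(-c3ccccc3)c(-c3ccc4c(c3)NC(=O)CO4)[nH]2)cc1`: 96%
Compound 2 `O=C1COc2ccc(-c3nn(-c4ccc(Cl)cc4)cc3-c3ccccc3)cc2N1`: 61.9%
Compound 3 `O=C1COc2ccc(-c3[nH]c(-c4c[nH]c5ncccc45)nc3-c3ccccc3)cc2N1`: 97.7%

Compound 3 shows the highest of the three numbers, yet its nearest neighbour, compound 1, lies within the usual scatter of it, the change being a number 1.7 percentage points higher from compound 1 to compound 3 (within the scatter). Compound 2 alone gives a clearly lower number.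

Compound 4 `O=C1COc2ccc(-c3[nH]c(-c4ccccc4)nc3-c3ccccc3)cc2N1` differs from compound 3 in one place: a group of 6 heavy atoms (6 carbon; one six-membered aromatic ring of carbon only) in place of a group of 9 heavy atoms (7 carbon, 2 nitrogen; one five-membered aromatic ring with 1 hetero atom, one six-membered aromatic ring with 1 hetero atom), on an aromatic carbon. Among the compounds with values here, the one measured step that bears on this is the one that brought in the same group of 9 heavy atoms, a number 1.7 percentage points higher from compound 1 to compound 3 (within the scatter), which stayed within the scatter. Removing that group again in favour of a phenyl is therefore expected to give no step beyond the scatter, a number 1.7 percentage points lower from compound 3 to compound 4 (within the scatter). Compound 4 is estimated at 96%, in a range from 85% to 104%.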

Compound 4, a percentage reported as activity, at one concentration (the size of the read-out at that concentration, not a potency): 98.2%
Compound 4: middle estimate off by 2.2 percentage points, on the low side; the measured number falls inside the stated range.
By their numbers in this assay, from the lowest: compound 2; then compounds 1, 3 and 4 (each within the scatter of the next).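

On the aromatic carbon between two ring nitrogen atoms, swapping the larger two-ring group for phenyl leaves the read-out in this assay within the scatter, a number 0.5 percentage points higher from compound 3 to compound 4 (within the scatter). Hydrogen in place of methoxy on that phenyl also stays within the scatter, a number 2.2 percentage points higher from compound 1 to compound 4 (within the scatter), so these three groups at this position cannot be told apart in this read-out. Nothing available explains this sameness.

Still open, going by these compounds, is whether an amine or a carboxylic acid on that phenyl, or a longer chain at this position, would move the number beyond the scatter.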